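The source may report more compounds than this note shows. Statements on the series, on what has been measured and on what is new or still open speak of the compounds shown alone.

Compound 1, `CNc1nc(NCc2ccc(NC(C)=O)cc2)cc(-c2ccccn2)n1`, is tested in a functional assay on HEK293 cells for agonist activity at G-protein coupled receptor 39 (Homo sapiens), read by inositol phosphate accumulation (on this read-out lower numbers stand for an effect already at smaller amounts and higher numbers for an effect only at larger amounts of compound), where compound 1 gives 5 nM. Among the measured compounds shown here, its only measured neighbour is compound 2, `CNc1nc(NCc2ccc(NS(C)(=O)=O)cc2)cc(-c2ccccn2)n1`, and in this assay compound 2 gives 3 nM. The step between them is a 1.7-fold lower number from compound 1 to compound 2 (0.22 log units; within the scatter), so the two values cannot be told apart. For the measured compounds named here, of the two numbers known, compound 1 stands at the upper end, with compound 2 as its only comparison and that one within the scatter.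

Compound 3, `CNc1nc(NCc2ccc(NC(C)=O)cc2F)cc(-c2ccccn2)n1`, keeps the acetamido group of compound 1 and differs from it in one place: fluoro in place of hydrogen on an aromatic carbon. Going by the values given here, no measured pair shows what a fluoro in place of hydrogen on this ring does. Among the compounds with values here, the one step at hand, a 1.7-fold lower number from compound 1 to compound 2 (0.22 log units; within the scatter), concerns the group on the ring nitrogen and leaves the ring carbons untouched, so it offers no guide to the present change. Compound 3 is therefore expected to show a step of no change at the digits printed from compound 1 to compound 3 (within the scatter), estimated to stay within the scatter. Compound 3 is thus expected to give 5 nM, with the estimate ranging from 1.5 nM to 15 nM.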

Compound 3, half-maximal effective concentration: 1 nM
Compound 3: middle estimate off by 5.0-fold (0.70 log units), on the high side; measured number outside the range, below it.
By their numbers in this assay, from the lowest: compound 3; then compounds 2 and 1 (each within the scatter of the next).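

Fluoro in place of hydrogen on this aromatic carbon, ortho to a large group and meta to the acetamido group, gives a 5.0-fold lower number from compound 1 to compound 3 (0.70 log units; beyond the scatter) in this assay. The earlier pair changed only the group on the ring nitrogen and stayed within the scatter, so this is the first step among the compounds shown that lies beyond it. It shows that the ring carbons are not indifferent to change in this assay, since the entering group here is a single fluorine atom with no ring and no net charge.

The compounds shown leave open whether a larger group on the same carbon, such as chloro, methyl or methoxy, would move the number in the same direction as fluoro. They also leave open whether fluoro at this place would do the same alongside the methylsulfonyl group of compound 2, and whether fluoro on the other carbons of this ring would matter at all.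

No measurement at hand bears on what lies behind this step.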